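The compounds below may be only part of what the source reports. "The series", "measured", "known", "first", "only" and "open" are said of these compounds alone.

Of the compounds shown here, three sharing one core have been measured in a functional assay on CHO-K1 cells for antagonist activity at melanin-concentrating hormone receptor 1 (Homo sapiens), read by inositol phosphate accumulation, with stated times of 10 min and 45 min; on this read-out lower numbers stand for stronger inhibition and higher numbers for weaker inhibition. Compound 1 `Cc1nc(NCCNC(=O)C2CC2)nc2ccc(NC(=O)/C=C/c3ccc(OC(F)(F)F)cc3)cc12` gives 23 nM. Compound 2 `Cc1nc(N2CCC(N3CCN(C)C3=O)CC2)nc2ccc(NC(=O)/C=C/c3ccc(OC(F)(F)F)cc3)cc12` gives 21 nM. Compound 3 `Cc1nc(N2CCC(N3CCCC3=O)CC2)nc2ccc(NC(=O)/C=C/c3ccc(OC(F)(F)F)cc3)cc12` gives 12 nM, the lowest of the three numbers, yet its nearest neighbour compound 2 sits within the scatter, as a 1.8-fold lower number from compound 2 to compound 3 (0.24 log units; within the scatter) shows, and compound 1 does too, as a 1.9-fold lower number from compound 1 to compound 3 (0.28 log units; within the scatter) shows. On these three numbers compound 3 cannot be set apart from the other two.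

Compound 4 `Cc1nc(N2CCC(N3CCNC3=O)CC2)nc2ccc(NC(=O)/C=C/c3ccc(OC(F)(F)F)cc3)cc12` has not yet been measured. It differs from compound 3 in one place: 2-oxoimidazolidin-1-yl in place of 2-oxopyrrolidin-1-yl on a saturated ring carbon.

Within the data shown here, only one measured step bears directly on this change. Going from compound 2 to compound 3 swapped a 3-methyl-2-oxoimidazolidin-1-yl for a 2-oxopyrrolidin-1-yl on the same saturated ring carbon, and the number moved by a 1.8-fold lower number from compound 2 to compound 3 (0.24 log units; within the scatter), within the scatter. Compound 4 reverses that swap but without the methyl, so it lies between compound 2 and compound 3 in structure. The expectation is therefore a step of a 1.5-fold higher number from compound 3 to compound 4 (0.18 log units; within the scatter) in this assay, with no movement beyond the scatter likely. Compound 4 is expected to give about 18 nM, with a range from 7 nM to 45 nM.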

Compound 4, half-maximal inhibitory concentration: 31 nM
Beside the measured number, compound 4's estimate is 1.7-fold (0.24 log units) below it, within the range that was stated.
By their numbers in this assay, from the lowest: compounds 3, 2, 1 and 4 (each within the scatter of the next, the first and the last beyond it).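

At the saturated ring carbon three ring bonds from the ring nitrogen, 2-oxoimidazolidin-1-yl in place of 2-oxopyrrolidin-1-yl gives a 2.6-fold higher number from compound 3 to compound 4 (0.41 log units; beyond the scatter) in this assay, a modest step but the only one in this set that passes the scatter, so the two rings are not interchangeable here, even though they have the same ring size and the entering ring differs by a ring nitrogen bearing 1 hydrogen-bond donor. The other two steps stay small: hydrogen in place of methyl on the amide-type nitrogen gives a 1.5-fold higher number from compound 2 to compound 4 (0.17 log units; within the scatter), and the change from the open (2-((cyclopropylcarbonyl)amino)ethyl)amino chain to the 4-(2-oxoimidazolidin-1-yl)piperidin-1-yl group gives a 1.3-fold higher number from compound 1 to compound 4 (0.13 log units; within the scatter), so compound 4 cannot be told apart from either compound 2 or compound 1. Among these compounds, nothing available explains why the one step passes the scatter.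

On these data alone, all the ring groups at this carbon are five-membered and carry a carbonyl, so the effect of a six-membered 2-oxopiperidin-1-yl ring, a plain amine or a carboxylic acid there remains open. Also open, as far as these compounds go, is whether the step seen with this pair would recur on a different core.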